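Fluorine Added to a Compound at the Cytotoxicity Limit

The source may report more compounds than this note shows. Statements on the series, on what has been measured and on what is new or still open speak of the compounds shown alone.

Compound 1 `NS(=O)(=O)c1ccc(N2N=C(c3ccc(Oc4ccccc4)cc3)CC2c2ccccc2F)cc1`: 36000 nM
Compound 2 `NS(=O)(=O)c1ccc(N2N=C(c3ccc(OCc4ccccc4)cc3)CC2c2ccccc2)cc1`: > 100000 nM

In an ADME assay on MT4 cells (Homo sapiens) for cytotoxicity, read by MTT assay, with a stated time of 96 h (on this read-out higher numbers stand for lower toxicity in this test and lower numbers for higher toxicity in this test), compound 1 gives 36000 nM. For compound 2 the result is only a limit, > 100000 nM, the assay reporting no exact number. This is the limit of > 100000 nM in this assay, at which 1 of the 2 values shown sits. Compound 3 `NS(=O)(=O)c1ccc(N2N=C(c3ccc(OCc4ccccc4)cc3)CC2c2ccccc2F)cc1` differs from compound 2 by fluoro in place of hydrogen on an aromatic carbon. Going by the values given here, no measured pair shows what this change does, so in this assay no step beyond the usual scatter is expected. Compound 3 is estimated at about 100000 nM, within 40000 nM to 250000 nM, which means an expected step of a number no higher from compound 2 to compound 3 (the limit leaves the size open).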

Compound 3, half-maximal cytotoxic concentration: 39000 nM
Estimate against measurement, compound 3: 2.6-fold (0.41 log units) above; the measured number lies below the stated range.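

In this assay, fluoro in place of hydrogen on this aromatic carbon, ortho to a large group, comes with an at least 2.5-fold lower number from compound 2 to compound 3 (0.40 log units; beyond the scatter), so the added fluorine does change the read-out, toward higher toxicity in this test. With the 2-fluorophenyl in place, benzyl in place of phenyl on the oxygen comes with a 1.1-fold higher number from compound 1 to compound 3 (0.03 log units; within the scatter). The value of compound 2 is a limit, so the full size of the first step stays unknown: the limit of > 100000 nM in this assay, at which 1 of the 3 values shown sits.

On these data alone, whether this step is special to fluoro stays open, since a chloro group, a methoxy group or an amine at the same carbon could behave differently. As far as these compounds go, how fluoro would act on the other carbons of that ring also stays open.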